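Methyl on the Hydroxyethyl Oxygen: A Small Step

This account rests on a few compounds, and the source may have more. Where it says the series, first, only, none or still open, it means among the compounds named here.

Measured compounds:
- compound 1, `COc1cc(/C=C/C(=O)/C=C(/C=C/c2ccc(O)c(OC)c2)NCCO)ccc1O`, gives 103%
- compound 2, `COc1cc(/C=C/C2=CC(=O)CC(c3ccc(O)c(OC)c3)N2CCCO)ccc1O`, gives 95.6%
- compound 3, `O=C(/C=C(/C=C/c1ccc(O)cc1)NCCCO)/C=C/c1ccc(O)cc1`, gives 94.1%

In a functional assay on Caco-2 cells (Homo sapiens) for activation, read by fluorescence, tested at 1 uM (a lower number here means a stronger effect, a higher number a weaker effect of the compound at the concentration tested), compound 1 gives the highest of the three numbers, yet its gap to compound 2 and its gap to compound 3 both lie within the usual scatter, so no order among the three can be read from these values. All three numbers sit close to the level where the compound has little or no effect at the concentration tested.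

Compound 4, `COCCNC(=C\C(=O)/C=C/c1ccc(O)c(OC)c1)/C=C/c1ccc(O)c(OC)c1`, is not yet measured. It differs from compound 1 in one place: methyl in place of hydrogen on an oxygen on a saturated carbon. This is a change of a single atom at the end of the 2-hydroxyethyl chain, turning it into a 2-methoxyethyl chain.

Within the data shown here, no step between two measured compounds is known, so there is nothing to lean on for the size of this change. Given that compound 1 gives 103% in this assay, the step from compound 1 to compound 4 is expected to be small, a number 4 percentage points lower from compound 1 to compound 4 (within the scatter), with no direction beyond the scatter. Compound 4 is therefore estimated at 99%, within a range from 85% to 112%.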

Compound 4, a percentage reported as activity, at one concentration (the size of the read-out at that concentration, not a potency): 105%
For compound 4 the middle estimate is 6 percentage points below the measured one; measured number inside the range.
By their numbers in this assay, from the lowest: compounds 3, 2, 1 and 4 (each within the scatter of the next, the first and the last beyond it).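

In this assay, among these compounds, turning the 2-hydroxyethyl chain into a 2-methoxyethyl chain gives a number 2 percentage points higher from compound 1 to compound 4 (within the scatter), the first step in this set that alters a single place, and the two numbers cannot be told apart. At the concentration tested, methyl can therefore take the place of the hydrogen on this oxygen without a measurable difference, although both compounds sit near the level of little or no effect, where a difference might not show. Nothing available bears on the cause of this result.

From the compounds shown here alone, whether a larger group on this oxygen, such as benzyl, or a chain ending in an amine or a carboxylic acid would move the number beyond the scatter stays open. Going by these compounds, the same change also remains unknown on the cores of compound 2 and compound 3.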